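This account rests on a few compounds, and the source may have more. Where it says the series, first, only, none or still open, it means among the compounds named here.

Working notes on the series. Going by the values given here, compound 1 `Cc1ccc(CN2C(=O)S/C(=C\c3ccc(F)cc3)C2=O)cc1` has been run in a functional assay on the whole organism (plasma) with Mus musculus as the target, with a stated time of 15 days, at a dose of 30 mg/kg by the oral route; on this read-out lower numbers stand for a weaker effect and higher numbers for a stronger effect at the one dose given; in that assay compound 1 gives 13.5%, the lowest of the three numbers measured so far. Compound 2 `COc1ccc(/C=C2\SC(=O)N(Cc3ccc(C)cc3)C2=O)c(OC)c1` gives 34.6% in this assay, and compound 3 `Cc1ccc(CN2C(=O)S/C(=C\c3ccccc3Cl)C2=O)cc1` gives 43.3% in this assay. Among the compounds with values here, the only measured step at a single place is a number 29.8 percentage points higher from compound 1 to compound 3 (beyond the scatter). Within the data shown here, compound 2 differs from compound 1 in more than one place, so its two values show only that compound 2 sits above compound 1.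

Compound 4 `Cc1ccc(CN2C(=O)S/C(=C\OCc3ccccc3)C2=O)cc1` has not yet been measured in this assay. It differs from compound 1 as follows: benzyloxy in place of 4-fluorophenyl on a double-bonded chain carbon bound to a double-bonded ring carbon. Among the measured compounds shown here, the one step that bears on this exchange is a number 29.8 percentage points higher from compound 1 to compound 3 (beyond the scatter), which went up beyond the scatter; compound 2 carries a differently substituted ring at the same chain carbon and also sits above compound 1. A benzyloxy group is of a different kind from either of those rings, so that step is only a loose guide to direction, and the scatter leaves room for no change at all.

On this basis compound 4 is expected to give 27% in this assay, within a range of 5% to 50%. The step this estimate implies is a number 13.5 percentage points higher from compound 1 to compound 4 (beyond the scatter), expected to be modest.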

Compound 4, a percentage reported as activity, at one dose (the size of the read-out at that dose, not a potency): 20.2%
Compound 4: middle estimate off by 6.8 percentage points, on the high side, and the stated range covers the measured number.
By their numbers in this assay, from the lowest: compounds 1 and 4 (each within the scatter of the next); then compounds 2 and 3 (each within the scatter of the next).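

In this assay, benzyloxy in place of 4-fluorophenyl on a double-bonded chain carbon bound to a double-bonded ring carbon gives a number 6.7 percentage points higher from compound 1 to compound 4 (within the scatter), so this exchange cannot be told apart from no change. Benzyloxy in place of 2-chlorophenyl at the same carbon gives a number 23.1 percentage points lower from compound 3 to compound 4 (beyond the scatter), so the rise seen with 2-chlorophenyl does not carry over to benzyloxy, and the earlier step is now shown to hold for that one exchange rather than for any replacement of 4-fluorophenyl at this place. No measurement on hand accounts for the difference between these groups.

The compounds shown leave open whether the higher number for compound 3 belongs to the chlorine or to the ring that carries it, a question that a plain phenyl or a 2-fluorophenyl at this carbon would address. They also leave open how this assay would read with a group of another kind at this place, such as an amine, a carboxylic acid or a longer chain in place of benzyloxy.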